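A few compounds are considered here, and "the series" means these few. Any claim that something is new, unique, unknown or untested is made for them only; others in the source may bear on it.

Solubility in the series is followed in a physicochemical assay for solubility, in phosphate buffer, at pH 7.4; a lower number here means a less soluble compound, a higher number a more soluble compound. Compound 1 `CCOC(=O)c1c(-c2cccc(Cl)c2)[nH]c2cccc(OC)c2c1=O` gives only a limit in this assay, > 100000 nM. Within the data shown here, compound 2 `CCOC(=O)c1c(-c2ccc(Cl)c(Cl)c2)[nH]c2cccc(OC)c2c1=O` gives 39000 nM, and the step of an at least 2.5-fold lower number from compound 1 to compound 2 (0.40 log units; beyond the scatter) is the one measured change in this assay; the only evidence beside it is the limit of > 100000 nM in this assay, at which 1 of the 3 values shown sits. Compound 3 `CCOC(=O)c1c(-c2ccc(C(C)(C)C)cc2)[nH]c2cccc(OC)c2c1=O` gives 1000 nM in this assay, the lowest of the numbers shown, with compound 2 nearest above it. Compound 4 `CCOC(=O)c1c(-c2ccc(C(F)(F)F)cc2)[nH]c2cccc(OC)c2c1=O` differs from compound 3 by trifluoromethyl in place of tert-butyl on an aromatic carbon. Among the measured compounds shown here, no measured step covers trifluoromethyl in place of tert-butyl, so only a modest shift upward in this assay is expected. Compound 4 is estimated at 3000 nM, between 700 nM and 15000 nM. The step of a 3.0-fold higher number from compound 3 to compound 4 (0.48 log units; beyond the scatter) is thus the expected change.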

Compound 4, solubility: 22000 nM
Compound 4: the middle estimate sits 7.3-fold (0.87 log units) below what was measured; measured number above the stated range.
By their numbers in this assay, from the lowest: compound 3; then compounds 4 and 2 (each within the scatter of the next). At a limit, above all of these: compound 1.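

Trifluoromethyl in place of tert-butyl on the aromatic carbon gives a 22-fold higher number from compound 3 to compound 4 (1.34 log units; beyond the scatter) in this assay, although both groups count the same number of heavy atoms and neither carries a hydrogen-bond donor or acceptor. Among these compounds, at this position, then, the read-out can shift strongly between groups that match on those counts, which the earlier compounds did not show.

Going by these compounds, how an amine or a carboxylic acid at the same position would read remains open. No measurement shown accounts for the size of this step.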